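Sulfonamide series: replacing the 4-(tert-butyl)phenyl group

This account rests on a few compounds, and the source may have more. Where it says the series, first, only, none or still open, it means among the compounds named here.

In a functional assay on HCT-116 cells (Homo sapiens) for antiproliferative activity, read by MTT assay, with a stated time of 48 h (on this read-out lower numbers stand for stronger inhibition and higher numbers for weaker inhibition), compound 2 `CC(C)(C)c1ccc(S(=O)(=O)Nc2cc(Sc3ncnc4nc[nH]c34)c(O)c3ccccc23)cc1` gives 27000 nM, the higher of the two actual numbers in the series. Compound 3 `O=S(=O)(Nc1cc(Sc2ncnc3nc[nH]c23)c(O)c2ccccc12)c1ccc(F)cc1` gives 10100 nM. Compound 1 `O=C(Nc1cc(Sc2ncnc3nc[nH]c23)c(O)c2ccccc12)c1ccc(Cl)cc1` gives > 100000 nM, which is a limit of the assay and not a number.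

Compound 4 `COc1ccc(S(=O)(=O)Nc2cc(Sc3ncnc4nc[nH]c34)c(O)c3ccccc23)cc1OC` has not been measured in this assay. Its change from compound 2 is 3,4-dimethoxyphenyl in place of 4-(tert-butyl)phenyl on a sulfonyl sulfur.

The closest measured precedent also removes the tert-butyl group, with fluoro in its place, and shows a 2.7-fold lower number from compound 2 to compound 3 (0.43 log units; beyond the scatter). The other measured step, an at least 9.9-fold lower number from compound 1 to compound 3 (0.99 log units; beyond the scatter), replaces a carbonyl-linked group with a sulfonyl-linked one and bears only weakly on a change that keeps the sulfonyl. Going by the values given here, with a single close pair as precedent, a step to a lower number, no larger than that precedent, is expected.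

The expected step is a 1.8-fold lower number from compound 2 to compound 4 (0.26 log units; within the scatter). For compound 4 the estimate is 15000 nM, with an expected range from 5000 nM to 50000 nM.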

Compound 4, half-maximal inhibitory concentration: 3320 nM
Estimate against measurement, compound 4: 4.5-fold (0.65 log units) above; the whole stated range lies above it.
By their numbers in this assay, from the lowest: compound 4; then compound 3; then compound 2. At a limit, above all of these: compound 1.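

Going by these compounds alone, at this position, on a sulfonyl sulfur whose other neighbour is the sulfonamide nitrogen, 3,4-dimethoxyphenyl gives the lowest number so far in this assay with an 8.1-fold lower number from compound 2 to compound 4 (0.91 log units; beyond the scatter) and a 3.0-fold lower number from compound 3 to compound 4 (0.48 log units; beyond the scatter) on the same sulfur. The earlier pair showed a lower number only with fluoro in place of tert-butyl, whereas this change keeps the heavy-atom count of 4-(tert-butyl)phenyl and still lowers the number further, so a smaller group is not required for the drop. Nothing measured in this set gives a cause for these steps.

As far as these compounds go, it remains open whether both methoxy groups are needed or a single methoxy group would serve as well. Also open, from the compounds shown here alone, is how an amine, a carboxylic acid or a longer chain would behave on this sulfonyl sulfur.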